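Sulfonamide aryl swap: from dimethylphenyl to bromophenyl

This account rests on a few compounds, and the source may have more. Where it says the series, first, only, none or still open, it means among the compounds named here.

Compound 1, `Cc1ccc(C2CCN(S(=O)(=O)c3c(C)cc(C)cc3C)CC2)cc1`: 2200 nM
Compound 2, `Cc1ccc(S(=O)(=O)N2CCC(N3CCC(C)CC3)CC2)cc1C`: 24 nM
Compound 3, `CC1CCN(C2CCN(S(=O)(=O)c3sc(Cl)nc3C3CC3)CC2)CC1`: > 5000 nM (a limit)

In a functional assay on DLD-1 cells (Homo sapiens) for antiproliferative activity, read by CellTiter-Glo, with a stated time of 72 h (on this read-out lower numbers stand for stronger inhibition and higher numbers for weaker inhibition), compound 2 gives 24 nM, the lowest of the two numbers shown; compound 1 sits at a much higher number in this assay. Compound 3 reaches only a limit of this assay and gives no number. the limit of > 5000 nM in this assay, at which 1 of the 3 values shown sits. The untested compound 4, `CC1CCN(C2CCN(S(=O)(=O)c3cccc(Br)c3)CC2)CC1`, carries the same piperidinyl-piperidine part as compound 2 and differs in one place: 3-bromophenyl in place of 3,4-dimethylphenyl on a sulfonyl sulfur. Going by the values given here, no measured pair isolates this change, so the expectation rests on compound 2 alone. A modest loss is expected, within or just beyond the scatter, giving a 3.3-fold higher number from compound 2 to compound 4 (0.52 log units; beyond the scatter). Compound 4 is estimated at 80 nM, between 20 nM and 400 nM.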

Compound 4, half-maximal inhibitory concentration: 3.2 nM
Compound 4: middle estimate off by 25-fold (1.40 log units), on the high side; measured number below the stated range.
By their numbers in this assay, from the lowest: compound 4; then compound 2; then compound 1. At a limit, above all of these: compound 3.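

In this assay, 3-bromophenyl in place of 3,4-dimethylphenyl on a sulfonyl sulfur gives a 7.5-fold lower number from compound 2 to compound 4 (0.88 log units; beyond the scatter) and is the only step shown that isolates this position. With the piperidinyl-piperidine part held fixed, the aryl group on the sulfonyl sulfur can thus be changed while the number still falls. The compounds shown give no measured reason for this fall.

From the compounds shown here alone, because the step swaps both methyl groups for one bromine, it remains open which of these changes carries it. Also open, going by these compounds, is how a nitrile or a carboxylic acid in place of the bromine would read.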